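This account rests on a few compounds, and the source may have more. Where it says the series, first, only, none or still open, it means among the compounds named here.

Compound 1 `CCCc1ccc(/C=C/C(=O)Nc2ccc3nc(CCC)cc(N)c3c2)cc1`: 3600 nM; compound 2 `CCCc1cc(NC2CCC2)c2cc(NC(=O)/C=C/c3ccc(C(F)(F)F)cc3)ccc2n1`: 270 nM.

In a functional assay on HEK293 cells for activation of melanin-concentrating hormone receptor 1 (Homo sapiens), read by inositol phosphate accumulation (a higher number here means that more compound is needed for the effect, a lower number that less compound is needed), compound 2 holds the lowest of the two numbers; compound 1 stands at a higher number, a gap beyond the scatter. Compound 3 `CCCc1cc(N2CCC2)c2cc(NC(=O)/C=C/c3ccc(C(F)(F)F)cc3)ccc2n1` differs from compound 2 in one place: azetidin-1-yl in place of cyclobutylamino on an aromatic carbon. Going by the values given here, no measured pair shows this change, so its size rests on estimate alone. A step of a 2.2-fold higher number from compound 2 to compound 3 (0.35 log units; beyond the scatter) toward a higher number is expected, possibly reaching beyond the scatter. Compound 3 is estimated at 600 nM, with a range from 200 nM to 2000 nM.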

Compound 3, half-maximal effective concentration: 2500 nM
Compound 3: the middle estimate sits 4.2-fold (0.62 log units) below what was measured, outside the stated range (above it).
By their numbers in this assay, from the lowest: compound 2; then compounds 3 and 1 (each within the scatter of the next).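

Going by these compounds alone, replacing cyclobutylamino with azetidin-1-yl on this aromatic carbon, opposite the ring nitrogen, gives in this assay a 9.3-fold higher number from compound 2 to compound 3 (0.97 log units; beyond the scatter), so this position responds to a change of a single group, which the earlier compounds, differing in more than one place, could not show. The change removes the group's hydrogen-bond donor and one heavy atom, and this single pair cannot separate those two differences. Nothing available explains the step. Going by these compounds, it remains open whether cyclopentylamino or piperidin-1-yl at this position would give a lower or higher number, which would separate ring size from the amine hydrogen.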